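The compounds below may be only part of what the source reports. "The series", "measured", "known", "first", "only" and "open" are said of these compounds alone.

Compound 1 `O=C(NC1CCCC1)c1ccc(C#Cc2ccccc2)nc1` gives 30 nM in a functional assay on BHK cells for positive allosteric modulation of metabotropic glutamate receptor 5 (Homo sapiens), read by FLIPR and calcium flux; a lower number here means that less compound is needed, a higher number that more compound is needed for the effect. Compound 2 `O=C(NC1CCCCC1)c1ccc(C#Cc2ccccc2)nc1` gives 240 nM and stands highest of the two numbers; its nearest neighbour is compound 1, the step being an 8.0-fold higher number from compound 1 to compound 2 (0.90 log units; beyond the scatter). Compound 3 `CC1CCC(NC(=O)c2ccc(C#Cc3ccccc3)nc2)CC1` carries methyl in place of hydrogen on a saturated ring carbon. Going by the values given here, the only measured step, from compound 1 to compound 2, changed ring size, not substitution, so it bears on this change only loosely; nothing here speaks directly to adding a methyl on the saturated ring. A step within the scatter, or a small rise, is therefore expected for compound 3, namely a 1.3-fold higher number from compound 2 to compound 3 (0.10 log units; within the scatter). The estimate for compound 3 in this assay is 300 nM, range 100 nM to 900 nM.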

Compound 3, half-maximal effective concentration: 1200 nM
The estimate for compound 3 lay 4.0-fold (0.60 log units) below the measured number; measured number above the stated range.
By their numbers in this assay, from the lowest: compound 1; then compound 2; then compound 3.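

In this assay, the saturated ring carbon three ring bonds from the ring atom that bears a large group does not tolerate methyl in place of hydrogen freely, with a 5.0-fold higher number from compound 2 to compound 3 (0.70 log units; beyond the scatter). Taken with the ring change, 4-methylcyclohexyl in place of cyclopentyl gives a 40-fold higher number from compound 1 to compound 3 (1.60 log units; beyond the scatter), so both larger groups on the amide nitrogen raise the number, and no compound shown goes against this. No evidence bears on the origin of this rise. Open, from the compounds shown here alone, is whether a hydroxyl or an amine on the same ring carbon behaves like methyl, and how a cyclobutyl group on the amide nitrogen compares with cyclopentyl.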